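The source may report more compounds than this note shows. Statements on the series, on what has been measured and on what is new or still open speak of the compounds shown alone.

Measured so far:
- compound 1 `COc1cccc(CSc2nnc([C@@H](C)c3ccc4cc(OC)ccc4c3)n2-c2ccc(Cl)cc2)c1`: 162000 nM
- compound 2 `COc1ccc2cc([C@H](C)c3nnc(SCc4ccccc4)n3-c3ccc(Cl)cc3)ccc2c1`: 50400 nM

In a functional assay on LNCaP cells (Homo sapiens) for cytotoxicity, read by MTT assay (a higher number here means a weaker inhibitor, a lower number a stronger inhibitor), compound 2 has the lower of the two numbers, at 50400 nM. The next compound, compound 3 `COc1ccc2cc([C@H](C)c3nnc(SCc4ccc(C)cc4)n3-c3ccc(Cl)cc3)ccc2c1`, differs from it by methyl in place of hydrogen on an aromatic carbon: benzyl to 4-methylbenzyl, with the methyl para to a large group.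

Going by the values given here, only one measured step bears on this change: a 3.2-fold lower number from compound 1 to compound 2 (0.51 log units; beyond the scatter). That step also concerns a substituent on the benzyl ring, but it involves methoxy rather than methyl, so it is only a loose guide. In that single pair, the compound with the added group, compound 1, has the higher number at 162000 nM. A small move in the same direction is therefore expected, possibly no larger than the scatter. The expected step is a 1.4-fold higher number from compound 2 to compound 3 (0.14 log units; within the scatter). For compound 3 the estimated value is 70000 nM, with an expected range of 30000 nM to 160000 nM.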

Compound 3, half-maximal inhibitory concentration: 52200 nM
The estimate for compound 3 lay 1.3-fold (0.13 log units) above the measured number; low and high end bracket the measured number.
By their numbers in this assay, from the lowest: compounds 2 and 3 (each within the scatter of the next); then compound 1.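

In this assay, benzyl to 4-methylbenzyl gives a 1.0-fold higher number from compound 2 to compound 3 (0.02 log units; within the scatter), so with a methyl para to a large group, compound 2 and compound 3 cannot be told apart. The other new step, a 3.1-fold lower number from compound 1 to compound 3 (0.49 log units; beyond the scatter), shows that a substituent on this ring does not by itself go with a higher number: compound 3 carries methyl and sits with compound 2, while compound 1, with its 3-methoxyphenyl, stands apart. No measurement on hand accounts for the gap between the methoxy and methyl compounds.

From the compounds shown here alone, compound 1 and compound 3 differ in both the group and its place on the ring, so it remains open which of the two goes with the higher number of compound 1. Going by these compounds, a 4-methoxybenzyl would separate these, and it remains open how an amine or a carboxylic acid at this position would read.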